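The source may report more compounds than this note shows. Statements on the series, on what has been measured and on what is new or still open speak of the compounds shown alone.

Measured in a functional assay on KB cells (Homo sapiens) for inhibition, with a stated time of 72 h; on this read-out lower numbers stand for stronger inhibition and higher numbers for weaker inhibition:
Compound 1 `COc1ccc(S(=O)(=O)N2CCc3cccc(-c4ccc([N+](=O)[O-])cc4)c32)cc1`: 52.5 nM
Compound 2 `COc1ccc(S(=O)(=O)N2CCc3cccc(-c4cccnc4)c32)cc1`: 95.9 nM

Going by the values given here, compound 2 cannot be separated from compound 1, since the only measured step, a 1.8-fold higher number from compound 1 to compound 2 (0.26 log units; within the scatter), stays within the scatter. Compound 3 `COc1ccc(S(=O)(=O)N2CCc3cccc(-c4cccs4)c32)cc1` carries thiophen-2-yl in place of pyridin-3-yl on an aromatic carbon. Among the compounds with values here, the measured step exchanged a group on that same carbon, and it is the only guide available. No step beyond the scatter is therefore expected in this assay. The estimated step is a 1.4-fold lower number from compound 2 to compound 3 (0.14 log units; within the scatter). Compound 3 is expected at 70 nM, with an estimated range of 25 nM to 190 nM.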

Compound 3, half-maximal inhibitory concentration: 215 nM
For compound 3 the middle estimate is 3.1-fold (0.49 log units) below the measured one; measured number above the stated range.
By their numbers in this assay, from the lowest: compounds 1 and 2 (each within the scatter of the next); then compound 3.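

In this assay, going by these compounds alone, the group on this aromatic carbon now makes a difference beyond the scatter: thiophen-2-yl gives a 2.2-fold higher number from compound 2 to compound 3 (0.35 log units; beyond the scatter) and a 4.1-fold higher number from compound 1 to compound 3 (0.61 log units; beyond the scatter) as the first such steps at this position, both modest. The position therefore does not treat all aromatic groups alike, with thiophen-2-yl standing apart from pyridin-3-yl and 4-nitrophenyl. Nothing available explains this difference.

Going by these compounds, whether furan-2-yl, another five-membered aromatic ring, would follow thiophen-2-yl remains open. So does the effect of an amine or a carboxylic acid on this carbon.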